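Methoxy for phenyl on the core: cytotoxicity notes

The compounds below may be only part of what the source reports. "The series", "measured", "known", "first", "only" and "open" are said of these compounds alone.

Measured so far:
compound 1 `c1ccc(-c2ccc(Cn3cncc3CNc3ccc(-c4ccccc4)c(-c4ccccc4)c3)cc2)cc1` gives > 10000 nM, a limit
compound 2 `c1ccc(-c2ccc(Cn3cncc3CNc3ccc(-c4ccccc4)cc3)cc2)cc1` gives > 10000 nM, a limit
compound 3 `Cc1ccc(Cn2cncc2CNc2cccc(-c3ccccc3)c2)cc1` gives 10000 nM

In a toxicity assay on NIH3T3 cells (Mus musculus) for cytotoxicity, read by resazurin assay (on this read-out lower numbers stand for an effect already at smaller amounts and higher numbers for an effect only at larger amounts of compound), compound 1 stands at the assay limit, so only a bound is known, not a number. Compound 2 also sits at that limit. The step that the two limits leave unreadable from compound 1 to compound 2 is therefore unreadable because of the limit of > 10000 nM in this assay, at which 2 of the 3 values shown sit. Among the measured compounds shown here, compound 3 gives a number, but no single-point step connects it to compound 1.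

Compound 4 `COc1ccc(NCc2cncn2Cc2ccc(-c3ccccc3)cc2)cc1-c1ccccc1` differs from compound 1 by methoxy in place of phenyl on an aromatic carbon. For the measured compounds named here, no measured step covers this exchange, and the one measured step shows no readable size. No step beyond the scatter is expected. Compound 4 is expected near 10000 nM, within 5000 nM to 20000 nM. The step of a number no higher from compound 1 to compound 4 (the limit leaves the size open) is thus estimated as none beyond the scatter, most likely another limit.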

Compound 4, half-maximal effective concentration: > 1000 nM
Compound 4: only a limit was reported; the forecaster's own chance of this, stated with the estimate: 70%; the middle value lies beyond the limit too.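

In this assay compound 4 gives > 1000 nM, a limit. Among the compounds shown here, compound 1 is also only a limit, so no step between compound 1 and compound 4 can be read. The compounds shown leave open whether methoxy in place of phenyl shifts cytotoxicity at all.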